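Second nitro group on the benzylic aryl ring

The compounds below may be only part of what the source reports. "The series", "measured", "known", "first", "only" and "open" are said of these compounds alone.

Compound 2 `C=C(C(=O)c1ccc(OC)cc1)C(OC(=O)c1ccccc1)c1ccccc1[N+](=O)[O-]` gives 12700 nM in a functional assay on NB-4 cells (Homo sapiens) for inhibition, read by XTT assay, with a stated time of 48 h; a higher number here means a weaker inhibitor, a lower number a stronger inhibitor; compound 1 `C=C(C(=O)c1ccc(OC)cc1)C(OC(=O)c1ccccc1)c1ccc([N+](=O)[O-])cc1` gives 13200 nM, the only comparator, and the two lie within the scatter of each other, as the step of a 1.0-fold lower number from compound 1 to compound 2 (0.02 log units; within the scatter) shows. Compound 3 `C=C(C(=O)c1ccc(OC)cc1)C(OC(=O)c1ccccc1)c1ccc([N+](=O)[O-])cc1[N+](=O)[O-]` carries the change (nitro in place of hydrogen on an aromatic carbon), sitting meta to a nitro group and para to a large group. For the measured compounds named here, only the step from compound 1 to compound 2 bears on this move, and it left the number essentially unchanged, so in this assay the expected step is a 1.1-fold lower number from compound 2 to compound 3 (0.02 log units; within the scatter), nothing beyond the scatter. Compound 3 is therefore estimated at 12000 nM, within 4000 nM to 36000 nM.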

Compound 3, half-maximal inhibitory concentration: 10000 nM
Estimate against measurement, compound 3: 1.2-fold (0.08 log units) above, within the range that was stated.
By their numbers in this assay, from the lowest: compounds 3, 2 and 1 (each within the scatter of the next).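

In this assay, nitro in place of hydrogen on an aromatic carbon, meta to a nitro group and para to a large group, stays within the scatter, with a 1.3-fold lower number from compound 2 to compound 3 (0.10 log units; within the scatter) and a 1.3-fold lower number from compound 1 to compound 3 (0.12 log units; within the scatter). The earlier compounds shown here showed only a nitro group at two different places; these steps show that a ring carrying two nitro groups also gives a number within the scatter of both. No evidence on the mechanism accompanies these values.

From the compounds shown here alone, whether an amine or a carboxylic acid at this position would give a step beyond the scatter remains open.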